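Shortening a fluorinated ether chain on a shared core

This account rests on a few compounds, and the source may have more. Where it says the series, first, only, none or still open, it means among the compounds named here.

Of the compounds shown here, two with a shared core have been measured. Compound 1 `Oc1nc2nonc2nc1Nc1ccc(OCCCC(F)(F)F)c(F)c1` carries a 4,4,4-trifluorobutoxy group on its outer aromatic ring, while compound 2 `Oc1nc2nonc2nc1Nc1cccc(F)c1` has only a hydrogen at that position. In an assay on mitochondria from L6 cells (Rattus norvegicus) for activation, with a stated time of 90 min (on this read-out lower numbers stand for an effect already at smaller amounts and higher numbers for an effect only at larger amounts of compound), compound 1 gives 4200 nM and compound 2 gives 31200 nM. Going by the values given here, compound 2 thus stands at the highest number of the two, and the only step known so far, a 7.4-fold higher number from compound 1 to compound 2 (0.87 log units; beyond the scatter), shows how much is lost when the chain is removed.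

Compound 3 `Oc1nc2nonc2nc1Nc1ccc(OC(F)(F)F)c(F)c1` is the compound not yet measured. It differs from compound 2 by trifluoromethoxy in place of hydrogen on an aromatic carbon, and this trifluoromethoxy group sits ortho to a fluoro group and para to a large group. The step of a 7.4-fold higher number from compound 1 to compound 2 (0.87 log units; beyond the scatter) is the one that bears on this change: adding a fluorinated ether at this aromatic carbon lowered the number markedly. The new group is shorter than 4,4,4-trifluorobutoxy, so a smaller but still clear drop in this assay is expected, of about a 3.9-fold lower number from compound 2 to compound 3 (0.59 log units; beyond the scatter). Compound 3 is therefore estimated at 8000 nM, with a range from 3000 nM to 25000 nM.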

Compound 3, half-maximal effective concentration: 2900 nM
For compound 3 the middle estimate is 2.8-fold (0.44 log units) above the measured one; the measured number lies below the stated range.
By their numbers in this assay, from the lowest: compounds 3 and 1 (each within the scatter of the next); then compound 2.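

The new compound shows that the gain at this aromatic carbon does not need a long chain: in this assay adding the small trifluoromethoxy group alone gives an 11-fold lower number from compound 2 to compound 3 (1.03 log units; beyond the scatter) and so accounts for a large step on its own. Replacing the longer chain with the short one gives a 1.4-fold lower number from compound 1 to compound 3 (0.16 log units; within the scatter) and so 4,4,4-trifluorobutoxy and trifluoromethoxy cannot be told apart on this read-out, which means the extra length brings nothing that can be detected here. No independent data are at hand to explain why this group has such an effect at this position.

The compounds shown leave open how much of the drop belongs to the fluorine atoms and how much to the ether oxygen; a plain methoxy group and a trifluoromethyl group set directly on the ring would speak to that. On these data alone, it also remains open whether only fluorinated ethers lower the number at this carbon, or whether an amine or a carboxylic acid placed there would do the same.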